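This account rests on a few compounds, and the source may have more. Where it says the series, first, only, none or still open, it means among the compounds named here.

Of the compounds shown here, three of one shared core have been measured in a functional assay on OE19 cells (Homo sapiens) for cytotoxicity, read by MTT assay, with a stated time of 48 h; a higher number here means a weaker inhibitor, a lower number a stronger inhibitor. Compound 1, `CC1(C)S[C@@H]2/C(=C\C(=O)c3cc(C(F)(F)F)cc(C(F)(F)F)c3)C(=O)N2[C@H]1C(=O)OC(c1ccccc1)c1ccccc1`, carries two trifluoromethyl groups on its aromatic ring and gives 48500 nM. Compound 2, `CC1(C)[C@H](C(=O)OC(c2ccccc2)c2ccccc2)N2C(=O)/C(=C/C(=O)c3ccc([N+](=O)[O-])cc3)[C@H]2[S+]1[O-]`, with a nitro group and an oxidised sulfur in its core, gives 92400 nM. Compound 3, `CC1(C)S[C@@H]2/C(=C\C(=O)c3ccccc3)C(=O)N2[C@H]1C(=O)OC(c1ccccc1)c1ccccc1`, with an unsubstituted benzoyl group, gives 12800 nM.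

On these numbers compound 3 stands lowest of the three. Its gap to compound 1 and its wider gap to compound 2 both lie beyond the scatter of repeated measurements, so among the three compound 3 is the strongest inhibitor.

Compound 4, `CC1(C)S[C@@H]2/C(=C\C(=O)c3ccc(Cl)cc3)C(=O)N2[C@H]1C(=O)OC(c1ccccc1)c1ccccc1`, is built from compound 3 by a single change: chloro in place of hydrogen on an aromatic carbon. Among the compounds with values here, no measured pair in this set differs by just one such exchange, so there is no direct step to lean on; compound 1 and compound 2 each differ from compound 3 in more than one place and can only show that heavier decoration of the benzoyl ring, or of the core, went with higher numbers.

With so little to go on, the step from compound 3 to compound 4 is expected to be small, a 1.2-fold higher number from compound 3 to compound 4 (0.07 log units; within the scatter), possibly none beyond the scatter. Compound 4 is therefore estimated at 15000 nM, in a range from 6000 nM to 40000 nM.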

Compound 4, half-maximal inhibitory concentration: 14600 nM
Beside the measured number, compound 4's estimate is 1.0-fold (0.01 log units) above it, and the stated range covers the measured number.
By their numbers in this assay, from the lowest: compounds 3 and 4 (each within the scatter of the next); then compounds 1 and 2 (each within the scatter of the next).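

In this assay, the exchange of hydrogen for chloro can finally be read on its own, as a step of a 1.1-fold higher number from compound 3 to compound 4 (0.06 log units; within the scatter), and the two compounds cannot be told apart in this assay. So this aromatic carbon, para to a large group, accepts a chlorine atom with no change beyond the scatter, something compound 1 and compound 2 could not show, since each differs from compound 3 in more than one place. No other measurement is at hand that bears on this result.

Going by these compounds, one group at one position is a narrow test, so it remains open whether a methoxy group, an amine or a carboxylic acid on this same carbon would also leave the number within the scatter, or would move it clearly in either direction. Also open, on these data alone, is whether chloro on another carbon of the ring would read the same, and whether the exchange would give the same small step on the oxidised core of compound 2.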